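Removing the benzyl group from compound 2

The source may hold more compounds than are shown below. What is called first, only, known or untested is meant among the compounds shown, and "the series" means these compounds.

In a functional assay on SGC-7901 cells (Homo sapiens) for antiproliferative activity, read by MTT assay, with a stated time of 72 h (a higher number here means a weaker inhibitor, a lower number a stronger inhibitor), compound 1 (`CCOC(=O)c1cc(-c2ccc(OC)c(O)c2)c(-c2cc(OC)c(OC)c(OC)c2)s1`) gives 20000 nM as its half-maximal inhibitory concentration, a measurable but modest value that carries a free hydroxy group.

Compound 2 (`COc1ccc(-c2ccsc2-c2cc(OC)c(OC)c(OC)c2)cc1OCc1ccccc1`) stands at > 100000 nM in this assay and this is a limit of the assay, not a number.

Compound 3 (`COc1ccc(-c2ccsc2-c2cc(OC)c(OC)c(OC)c2)cc1O`) follows from compound 2 with hydrogen in place of benzyl on an oxygen on an aromatic ring, which reads as benzyloxy to hydroxy. Going by the values given here, no measured pair isolates this change, so any expectation for it is poorly anchored.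

Among the compounds with values here, the only support is compound 1, which holds a hydroxy group and reaches 20000 nM in this assay as a true number. A strengthening well beyond the scatter is therefore expected, and the estimated move is an at least 100-fold lower number from compound 2 to compound 3 (2.00 log units; beyond the scatter) in size, with the starting point itself only a limit.

For compound 3 the expected value is 1000 nM with a deliberately wide estimated range of 30 nM to 30000 nM around it.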

Compound 3, half-maximal inhibitory concentration: 520 nM
Compound 3: the middle estimate sits 1.9-fold (0.28 log units) above what was measured, and the stated range covers the measured number.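

In this assay, hydrogen in place of benzyl on an oxygen on an aromatic ring gives an at least 190-fold lower number from compound 2 to compound 3 (2.28 log units; beyond the scatter), the first reading of this change in the series, and it shows that benzyloxy to hydroxy at this place separates a compound with no measured potency from the most potent one shown. From the compounds shown here alone, the value of compound 2 is a limit of the assay and not a number, so the true size of this step stays unknown: the limit of > 100000 nM in this assay, at which 1 of the 3 values shown sits. The second step shows that the hydroxy alone does not set the level, since hydrogen in place of ethoxycarbonyl on an aromatic carbon, with the hydroxy present on both sides, gives a 38-fold lower number from compound 1 to compound 3 (1.59 log units; beyond the scatter).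

Going by these compounds, what remains open at the oxygen is whether the free hydroxy is needed or whether a small group such as methoxy or a short ethoxy chain would hold the gain, and whether an amine could replace that oxygen altogether. At the aromatic carbon, the compounds shown do not tell how a carboxylic acid or a primary amide would compare with hydrogen and ethoxycarbonyl.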